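Adding one methyl to compound 2

The source may report more compounds than this note shows. Statements on the series, on what has been measured and on what is new or still open speak of the compounds shown alone.

In a functional assay on HeLa cells (Homo sapiens) for cytotoxicity, read by MTT assay, with a stated time of 48 h (a lower number here means a stronger inhibitor, a higher number a weaker inhibitor), compound 1 (`COc1cc(COCc2cn(Cc3cc(C)cnc3Cl)nn2)cc(OC)c1OC`) gives 264000 nM and compound 2 (`COc1cc(-c2cc(COCc3cn(Cc4cc(-c5ccccc5)cnc4Cl)nn3)on2)cc(OC)c1OC`) gives 43100 nM as the lower of the two numbers. The gap between them lies beyond the usual scatter, so compound 2 is the stronger inhibitor of this pair. Compound 3 (`COc1cc(-c2cc(COCc3cn(Cc4cc(-c5ccc(C)cc5)cnc4Cl)nn3)on2)cc(OC)c1OC`) departs from compound 2 by a single change (methyl in place of hydrogen on an aromatic carbon), methyl in place of hydrogen on an aromatic carbon, which turns phenyl to 4-methylphenyl. Within the data shown here, no measured pair yet shows what such a change does in this assay, and the two measured compounds differ in more than one place. The expected step of a 1.1-fold lower number from compound 2 to compound 3 (0.03 log units; within the scatter) is therefore small, with no firm direction and nothing beyond the scatter. Compound 3 is estimated at 40000 nM (expected range 18000 nM to 90000 nM).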

Compound 3, half-maximal inhibitory concentration: 35300 nM
Beside the measured number, compound 3's estimate is 1.1-fold (0.05 log units) above it; the measured number falls inside the stated range.
By their numbers in this assay, from the lowest: compounds 3 and 2 (each within the scatter of the next); then compound 1.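

In this assay, among these compounds, this is the first pair of compounds that differ in one place, and it gives a 1.2-fold lower number from compound 2 to compound 3 (0.09 log units; within the scatter). Methyl in place of hydrogen, on an aromatic carbon of a six-membered aromatic ring of carbon only and para to a large group, therefore produces no difference that can be told from the scatter, something the earlier compounds, which differ in more than one place, could not show. Phenyl and 4-methylphenyl cannot be separated in this assay on these numbers, and nothing measured here offers an explanation for that.

On these data alone, it remains open whether a different group at this position, such as an amine, a carboxylic acid or a longer chain, would give a step beyond the scatter. As far as these compounds go, it is also open whether methyl on another carbon of the same ring would behave as it does here.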